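Nitrophenyl Amide Tolerance on Lymphoid Cells: a Chloro Substituent

This account rests on a few compounds, and the source may have more. Where it says the series, first, only, none or still open, it means among the compounds named here.

Measured compounds:
Compound 1, `O=C(CSc1nncnc1-c1cccc2ccccc12)Nc1ccccc1[N+](=O)[O-]`: 142000 nM
Compound 2, `O=C(CSc1nncnc1-c1ccccc1Cl)Nc1ccccc1F`: 98000 nM

Of the compounds shown here, two sharing the same core have been tested in an ADME assay on MT4 cells (Homo sapiens) for cytotoxicity, read by MTT assay; a lower number here means that less compound is tolerated, a higher number that more compound is tolerated. In this assay compound 1 gives 142000 nM, and compound 2 gives 98000 nM. Compound 1 carries the higher of the two numbers, yet the gap to compound 2 lies within the usual scatter of repeated measurements, so the two cannot be told apart and neither counts as better tolerated than the other. Both sit at high concentrations, which is to say that the cells tolerate a good deal of either.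

Compound 3, `O=C(CSc1nncnc1-c1cccc2ccccc12)Nc1ccc([N+](=O)[O-])cc1Cl`, has not yet been measured. It differs from compound 1 in one place: 2-chloro-4-nitrophenyl in place of 2-nitrophenyl on an amide-type nitrogen. No comparison of the same kind exists among the measured compounds, so there is nothing to show how this change shifts the number. In this assay a step from compound 1 to compound 3 of no more than the usual scatter is expected, in no particular direction. Compound 3 is therefore estimated at 120000 nM, with a range from 50000 nM to 250000 nM. This estimate implies a step of a 1.2-fold lower number from compound 1 to compound 3 (0.07 log units; within the scatter) that stays within the scatter.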

Compound 3, half-maximal cytotoxic concentration: 150000 nM
Compound 3: the middle estimate sits 1.3-fold (0.10 log units) below what was measured; the measured number falls inside the stated range.
By their numbers in this assay, from the lowest: compounds 2, 1 and 3 (each within the scatter of the next).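

In this assay, for the compounds shown here, putting 2-chloro-4-nitrophenyl in place of 2-nitrophenyl on the amide-type nitrogen gives a 1.1-fold higher number from compound 1 to compound 3 (0.02 log units; within the scatter) and so offers the first direct comparison at this position, with no difference that can be told from the variation between repeated measurements. The swap is not a single small edit, since a chlorine enters and the two group names also number the nitro group differently, yet the cells' tolerance of compound 3 cannot be distinguished from that of compound 1. No measurement at hand offers an explanation for this result.

The compounds shown leave open whether a quite different group on the amide-type nitrogen, such as a phenyl ring bearing an amine or a carboxylic acid, would also stay within the scatter of compound 1 in this assay. They also leave open how a phenyl ring carrying only the chlorine, or a nitro group numbered 4 with no chlorine, would compare, so the two parts of this swap cannot be looked at separately.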